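The compounds below may be only part of what the source reports. "The series", "measured", "known", "first", "only" and "open" are said of these compounds alone.

Compound 1 `Cc1cc2c(c(N)nn2C)c(N2CCCCC2)n1` gives 16% in an assay on isolated protein for inhibition of serine/threonine-protein kinase D2 (Homo sapiens), read by mobility shift assay, tested at 30 uM; a lower number here means less inhibition, a higher number more inhibition at the concentration tested (going by the name of the read-out).
Compound 2 `COCCNc1nc(C)cc2c1c(N)nn2C` gives 4% in this assay.

For the measured compounds named here, compound 2 stands lowest of the two numbers in this assay; the only measured step, a number 12 percentage points lower from compound 1 to compound 2 (beyond the scatter), was modest and beyond the scatter. Compound 3 `Cc1cc2c(cn1)c(N)nn2C` differs from compound 2 by hydrogen in place of (2-methoxyethyl)amino on an aromatic carbon. That single step bears only loosely on this change, since it exchanged one group for another rather than removing one. Both measured numbers are low, leaving little room downward. Compound 3 is therefore expected to stay close to compound 2, a number 1 percentage points higher from compound 2 to compound 3 (within the scatter), with an estimated 5% and a range from -5% to 18%.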

Compound 3, a percentage reported as inhibition, at one concentration (the size of the read-out at that concentration, not a potency): -3%
Estimate against measurement, compound 3: 8 percentage points above; the measured number falls inside the stated range.
By their numbers in this assay, from the lowest: compounds 3 and 2 (each within the scatter of the next); then compound 1.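

In this assay hydrogen in place of (2-methoxyethyl)amino gives a number 7 percentage points lower from compound 2 to compound 3 (within the scatter) and so cannot be told apart from that chain at this position. Hydrogen in place of piperidin-1-yl gives a number 19 percentage points lower from compound 1 to compound 3 (beyond the scatter) and this shows that, of the two groups, only piperidin-1-yl stands clearly apart from bare hydrogen here, though all three numbers remain low.

A plain amino group, pyrrolidine or morpholine on this carbon would help show whether a ring is what matters. No measurement shown here explains the gap between the two groups.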